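The source may report more compounds than this note shows. Statements on the series, on what has been measured and on what is new or still open speak of the compounds shown alone.

Compound 3 `Cc1cnc2nc(-c3ccc(Cl)cc3)cc(O)c2c1` carries a methyl group that compound 1 `Oc1cc(-c2ccc(Cl)cc2)nc2ncccc12` lacks. In a functional assay on MDA-N cells (Homo sapiens) (on this read-out higher numbers stand for weaker inhibition of growth and lower numbers for stronger inhibition of growth), compound 3 gives 562 nM, while compound 1 gives 8320 nM. The step of a 15-fold higher number from compound 3 to compound 1 (1.17 log units; beyond the scatter) is hydrogen in place of methyl on an aromatic carbon. Compound 2 `COc1cccc(-c2cc(O)c3c(C)cc(C)nc3n2)c1` rests on a different core; the difference between the two cores is not broken down here. In this assay compound 2 sits at a limit of the assay, < 10 nM, as noted in the limit of < 10 nM in this assay, at which 1 of the 3 values shown sits. Compound 4 `COc1cccc(-c2cc(O)c3c(C)ccnc3n2)c1` arises from compound 2 by the same kind of change, (hydrogen in place of methyl on an aromatic carbon), though the place is not identical: here the carbon is next to the ring nitrogen and meta to a methyl group, whereas in compound 3 it was two atoms from the ring nitrogen. The starting point of compound 2 is known only as a limit. Resting on a 15-fold higher number from compound 3 to compound 1 (1.17 log units; beyond the scatter), a loss of comparable size, an at least 4.0-fold higher number from compound 2 to compound 4 (0.60 log units; beyond the scatter), is expected. Compound 4 is estimated at 40 nM, within a range from 6 nM to 300 nM.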

Compound 4, concentration for 50% growth inhibition: < 10 nM
Compound 4 was reported as a limit (the forecaster's own chance of this, stated with the estimate: 20%); at least 4.0-fold (0.60 log units) between middle value and limit.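

Compound 2 and compound 4 both stand at a limit of this assay, so the step between them cannot be read: the limit of < 10 nM in this assay, at which 2 of the 4 values shown sit.

The compounds shown leave open how much the methyl group lost from compound 2 matters for inhibition of growth.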